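Methoxy for methyl on the aryl urea of compound 2

The source may report more compounds than this note shows. Statements on the series, on what has been measured and on what is new or still open speak of the compounds shown alone.

Measured so far:
compound 1, `CN1CCC/C1=N\C(=O)Nc1c(Br)cccc1Br`, > 25 mg/kg
compound 2, `Cc1cccc(NC(=O)/N=C2\CCCN2C)c1`, 25 mg/kg

The two compounds were tested in a functional assay on the whole organism with Rattus norvegicus as the target, with a stated time of 5 days; a higher number here means that more compound is needed for the effect, a lower number that less compound is needed. Compound 1 gives > 25 mg/kg, which is a limit of the assay and not a number. Compound 2 gives 25 mg/kg, and this is the only number shown. The value of compound 1 is a limit (the limit of > 25 mg/kg in this assay, at which 1 of the 2 values shown sits). For the measured compounds named here, no step between measured compounds is available, so compound 2 stands alone as the one numerical reference.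

Compound 3, `COc1cccc(NC(=O)/N=C2\CCCN2C)c1`, has not yet been measured. It differs from compound 2 by methoxy in place of methyl on an aromatic carbon. Going by the values given here, nothing among the measured compounds tells how such a change shifts the minimum effective dose, so no step beyond the usual scatter is expected in this assay in either direction. For compound 3 the estimate is 25 mg/kg, with a range from 12 mg/kg to 50 mg/kg, which means an expected step of no change at the digits printed from compound 2 to compound 3 (within the scatter).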

Compound 3, minimum effective dose: > 25 mg/kg
Compound 3 gave a limit, no number; the forecaster's own chance of this, stated with the estimate: 45%; the middle value lies on the limit itself.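

In this assay, methoxy in place of methyl on an aromatic carbon, meta to a large group, gives a number no lower from compound 2 to compound 3 (the limit leaves the size open). Compound 3 gives > 25 mg/kg, which is a limit of the assay and not a number. This change therefore brought no value lower than that of compound 2, which remains the only compound with a number: the limit of > 25 mg/kg in this assay, at which 2 of the 3 values shown sit.

How far compound 3 lies from compound 2 stays open, and the compounds shown give no step of known size at this position. Also open, from the compounds shown here alone, is whether a chlorine, an amine, a carboxylic acid or a longer chain at this place would give a number that differs from that of compound 2.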